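The compounds below may be only part of what the source reports. "The series", "measured", "known", "first", "only" and "open" are said of these compounds alone.

For the measured compounds named here, in an ADME assay on HEK-293T cells (Homo sapiens) for cytotoxicity, read by MTT assay, with a stated time of 24 h (on this read-out lower numbers stand for higher toxicity in this test and higher numbers for lower toxicity in this test), three compounds with a shared core have numbers so far: compound 1 `O=S(=O)(c1ccccc1)n1c(-c2cn(-c3ccccc3)nc2-c2ccc(F)cc2)nc2ccccc21` gives 96300 nM, compound 2 `COc1ccc(S(=O)(=O)n2c(-c3cn(-c4ccccc4)nc3-c3ccc(F)cc3)nc3ccccc32)cc1` gives 37300 nM, and compound 3 `O=[N+]([O-])c1ccc(S(=O)(=O)n2c(-c3cn(-c4ccccc4)nc3-c3ccc(F)cc3)nc3ccccc32)cc1` gives 189000 nM. Compound 3 stands at the high end of this small set: a 2.0-fold higher number from compound 1 to compound 3 (0.29 log units; within the scatter) and a 5.1-fold higher number from compound 2 to compound 3 (0.70 log units; beyond the scatter). Compound 4 `O=S(=O)(c1ccc(C(F)(F)F)cc1)n1c(-c2cn(-c3ccccc3)nc2-c2ccc(F)cc2)nc2ccccc21` carries trifluoromethyl in place of nitro on an aromatic carbon. Going by the values given here, no measured step makes this exact swap. The closest guide is a 2.0-fold higher number from compound 1 to compound 3 (0.29 log units; within the scatter), where nitro replaces hydrogen, while a 2.6-fold lower number from compound 1 to compound 2 (0.41 log units; beyond the scatter), where methoxy replaces hydrogen, shows that this position can shift the number modestly. No step beyond the scatter is therefore expected in this assay, and the expected step is a 1.5-fold lower number from compound 3 to compound 4 (0.16 log units; within the scatter). For compound 4 the estimate is 130000 nM, with an expected range of 55000 nM to 290000 nM.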

Compound 4, half-maximal cytotoxic concentration: 241000 nM
Estimate against measurement, compound 4: 1.9-fold (0.27 log units) below; low and high end bracket the measured number.
By their numbers in this assay, from the lowest: compound 2; then compounds 1, 3 and 4 (each within the scatter of the next, the first and the last beyond it).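

In this assay, two different groups on this aromatic carbon, nitro and trifluoromethyl, cannot be told apart (a 1.3-fold higher number from compound 3 to compound 4 (0.11 log units; within the scatter)). Trifluoromethyl does separate from plain hydrogen (a 2.5-fold higher number from compound 1 to compound 4 (0.40 log units; beyond the scatter)), which nitro did not do, and it also stands clear of methoxy (a 6.5-fold higher number from compound 2 to compound 4 (0.81 log units; beyond the scatter)). Nothing available here explains these results. Still open, on these data alone, is how this position responds to an amine or a carboxylic acid in place of trifluoromethyl, and whether either would fall with methoxy or with nitro and trifluoromethyl.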